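Moving a Fluorine Across Three Weak Analogues

The source may report more compounds than this note shows. Statements on the series, on what has been measured and on what is new or still open speak of the compounds shown alone.

Compound 1: `Oc1cccc(-c2cc(-c3cccc(F)c3)cc(-c3ccccc3O)n2)c1`, > 50000 nM
Compound 2: `Oc1cccc(-c2cc(-c3ccc(F)cc3)cc(-c3ccccc3O)n2)c1`, > 50000 nM
Compound 3: `Oc1ccc(-c2cc(-c3cccc(F)c3)cc(-c3ccc(O)cc3)n2)cc1`, > 50000 nM

All three were tested in a functional assay on T47D cells (Homo sapiens) for inhibition; a higher number here means a weaker inhibitor, a lower number a stronger inhibitor. Compound 1 reaches only the limit of the assay, > 50000 nM. Compound 2 likewise gives only a limit, > 50000 nM. Compound 3 also sits at a limit, > 50000 nM. Hence the change 4-fluorophenyl in place of 3-fluorophenyl on an aromatic carbon yields a step that the two limits leave unreadable from compound 1 to compound 2, and the reading is bounded by the limit of > 50000 nM in this assay, at which 3 of the 3 values shown sit. How the core of compound 1 differs from the core of compound 3 is not broken down here.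

Compound 4, `Oc1ccc(-c2cc(-c3ccc(F)cc3)cc(-c3ccc(O)cc3)n2)cc1`, awaits measurement in this assay. It arises from compound 3 by 4-fluorophenyl in place of 3-fluorophenyl on an aromatic carbon, the same kind of change as from compound 1 to compound 2, though the surroundings differ: there the place was meta to a 2-hydroxyphenyl group and meta to a 3-hydroxyphenyl group, here it is meta to two 4-hydroxyphenyl groups. Since compound 3 shows only > 50000 nM, the step that the limit leaves unreadable from compound 3 to compound 4 is expected to remain unreadable. Compound 4 is expected to give about 100000 nM, between 20000 nM and 500000 nM.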

Compound 4, half-maximal inhibitory concentration: 5260 nM
Estimate against measurement, compound 4: 19-fold (1.28 log units) above; measured number outside the range, below it.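

In this assay, putting 4-fluorophenyl in place of 3-fluorophenyl on the core of compound 3 gives an at least 9.5-fold lower number from compound 3 to compound 4 (0.97 log units; beyond the scatter), so on this core the change has a readable effect. The same change on the core of compound 1 joins two limits, and its step from compound 1 to compound 2 cannot be read, so the data show neither that the gain carries over from one core to the other nor that it fails to. Even on the core of compound 3, the step gives only a lower bound on the size of the change, not its full size, and the limit shapes every comparison in this set: the limit of > 50000 nM in this assay, at which 3 of the 4 values shown sit.

The compounds shown leave open whether the gain is specific to fluorine, since a 4-chlorophenyl or 4-methoxyphenyl group opposite the ring nitrogen does not appear among them. They also leave open how an amine or a carboxylic acid on that phenyl ring would read in this assay.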